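The compounds below may be only part of what the source reports. "The series", "measured", "known", "first", "only" and "open" are said of these compounds alone.

Working notes on the series. The shared core of compound 1, `CCCn1c(=O)[nH]c2nc(-c3ccc(S(=O)(=O)N4CCN(c5cccc(Br)c5)CC4)cc3)[nH]c2c1=O`, is held throughout, with only the group on the amine nitrogen in the ring changing. In an assay on CHO cells for displacement of a labelled ligand from adenosine receptor A1 (Homo sapiens), read by scintillation counting, with a stated time of 90 min, tested at 1 uM, in the presence of a further agent that is not named here (a higher number here means more inhibition at the concentration tested (going by the name of the read-out), a lower number less inhibition), compound 1 gives -1%. Compound 2, `CCCn1c(=O)[nH]c2nc(-c3ccc(S(=O)(=O)N4CCN(c5cccc(F)c5)CC4)cc3)[nH]c2c1=O`, gives 34% in this assay, and the change is a number 35 percentage points higher from compound 1 to compound 2 (beyond the scatter). Compound 3, `CCCn1c(=O)[nH]c2nc(-c3ccc(S(=O)(=O)N4CCN(c5ccc(Cl)cc5F)CC4)cc3)[nH]c2c1=O`, gives 9% in this assay; it stands second highest of the three numbers, with the step of a number 10 percentage points higher from compound 1 to compound 3 (within the scatter) and the step of a number 25 percentage points lower from compound 2 to compound 3 (beyond the scatter).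

Compound 4 is `CCCn1c(=O)[nH]c2nc(-c3ccc(S(=O)(=O)N4CCN(C(C)c5ccccc5)CC4)cc3)[nH]c2c1=O`. Its difference from compound 3 is 1-phenylethyl in place of 4-chloro-2-fluorophenyl on an amine nitrogen in a ring. Within the data shown here, the steps that bear on this change are the two that swap the group on the amine nitrogen in the ring, a number 10 percentage points higher from compound 1 to compound 3 (within the scatter) and a number 25 percentage points lower from compound 2 to compound 3 (beyond the scatter): one within the scatter, one modest. Among the measured compounds shown here, neither step swaps an aromatic ring for a 1-phenylethyl group, so no measured step speaks directly to this change, and the spread of the three numbers from compound 1 to compound 2 marks the range seen so far.

For compound 4 a value in this assay is expected near 12%, between -15% and 40%, which is estimated to mean a number 3 percentage points higher from compound 3 to compound 4 (within the scatter), a step not clearly beyond the scatter.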

Compound 4, a percentage reported as inhibition, at one concentration (the size of the read-out at that concentration, not a potency): 42%
Compound 4: middle estimate off by 30 percentage points, on the low side, outside the stated range (above it).
By their numbers in this assay, from the lowest: compounds 1 and 3 (each within the scatter of the next); then compounds 2 and 4 (each within the scatter of the next).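

In this assay, the swap at the amine nitrogen in the ring gives a number 33 percentage points higher from compound 3 to compound 4 (beyond the scatter) and a number 43 percentage points higher from compound 1 to compound 4 (beyond the scatter), which shows that with 1-phenylethyl, built of carbon only, with the same count of heavy atoms as 4-chloro-2-fluorophenyl and also one six-membered aromatic ring, the number is higher and sits with the higher numbers of the series. Against 3-fluorophenyl the same kind of swap gives a number 8 percentage points higher from compound 2 to compound 4 (within the scatter), so compound 2 and compound 4 cannot be told apart here, and compound 2 stands against any reading that a halogen on the group always lowers the number. Nothing on hand explains why these groups differ.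

Open, on these data alone, is whether the difference follows the branching carbon of 1-phenylethyl or the loss of the halogens, a question that unsubstituted phenyl, benzyl or a longer chain such as 2-phenylethyl on the same nitrogen would bear on. Also open, as far as these compounds go, is how a halogen on the ring of 1-phenylethyl itself, or a non-aromatic group such as cyclohexyl, would read in this assay, where each number is the size of the read-out at a single concentration and not a potency.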